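The compounds below may be only part of what the source reports. "The series", "measured", "known", "first", "only" and "open" are said of these compounds alone.

Measured compounds:
Compound 1 `O=C(O)CC[C@H]1CCc2cc(-c3nc(OC4CCC4)ccc3F)ccc2O1` gives > 10000 nM in a functional assay on HEK293 cells for agonist activity at Free fatty acid receptor 1 (Homo sapiens), read by HTRF and inositol phosphate accumulation, with a stated time of 60 min (on this read-out higher numbers stand for an effect only at larger amounts of compound and lower numbers for an effect already at smaller amounts), which is a limit of the assay rather than a number.
Compound 2 `O=C(O)CC[C@H]1CCc2cc(-c3cc(OC4CCC4)cc(F)c3F)ccc2O1` gives > 10000 nM in this assay, again a limit.
Compound 3 `O=C(O)[C@H]1C[C@@H]1[C@H]1CCc2cc(-c3cc(OC(F)(F)F)ccc3F)ccc2O1` gives > 10000 nM in this assay, once more a limit.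

Compound 2 therefore stands at a limit of this assay, with no number known for it, and the two further values shown are limits as well: the limit of > 10000 nM in this assay, at which 3 of the 3 values shown sit. The account follows the step from compound 2 to compound 4 `O=C(O)CC[C@H]1CCc2cc(-c3cc(OC4CCC4)cc(Cl)c3F)ccc2O1`, which has not yet been measured in this assay. The change is chloro in place of fluoro on an aromatic carbon, at a carbon ortho to a fluoro group and meta to a cyclobutyloxy group. Within the data shown here, no step between measured compounds is known, so nothing measured tells the size of such a change here. Because compound 2 gives > 10000 nM, the step that the limit leaves unreadable from compound 2 to compound 4 is expected to be none beyond the scatter. Compound 4 is expected at 15000 nM, within a range from 4000 nM to 60000 nM, and most probably reported again only as a limit.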

Compound 4, half-maximal effective concentration: > 10000 nM
Compound 4: only a limit was reported; the forecaster's own chance of this, stated with the estimate: 75%; the middle value does not contradict the limit.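

No step can be read from compound 2 to compound 4, because both stand at a limit in this assay: the limit of > 10000 nM in this assay, at which 4 of the 4 values shown sit.

The compounds shown leave open whether chloro in place of fluoro on an aromatic carbon changes the half-maximal effective concentration at all.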